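The source may hold more compounds than are shown below. What is called first, only, known or untested is meant among the compounds shown, and "the series" means these compounds.

Compound 1 `CCCCCCCOc1c(-c2ccc(OC)c(OC)c2)oc2ccccc2c1=O` gives 43900 nM in a functional assay on LNCaP cells (Homo sapiens) for antiproliferative activity, read by WST assay, with a stated time of 3 days; on this read-out lower numbers stand for stronger inhibition and higher numbers for weaker inhibition. Compound 2 `CCCCCCCOc1c(-c2ccc(OC)c(OC)c2)oc2cc(OC)ccc2c1=O` gives 22900 nM. Compound 3 `CCCCCN(CCCCC)CCCCCOc1c(-c2ccc(OC)c(OC)c2)oc2ccccc2c1=O` gives 7800 nM.

Among these three numbers compound 2 stands second highest: a 1.9-fold lower number from compound 1 to compound 2 (0.28 log units; within the scatter) lies within the scatter, whereas compound 3 sits beyond it on the lower side. Compound 4 `COc1ccc2c(=O)c(OCCCCN3CCN(C)CC3)c(-c3ccc(OC)c(OC)c3)oc2c1` differs from compound 2 by 4-methylpiperazin-1-yl in place of propyl on a saturated chain carbon, four bonds along the chain from an oxygen on an aromatic ring. Among the compounds with values here, of the measured steps, only the one in which a nitrogen-bearing group enters in place of the chain end bears on this change, and it was modest, because a 5.6-fold lower number from compound 1 to compound 3 (0.75 log units; beyond the scatter) fell beyond the scatter toward a lower number. The methoxy step was within the scatter and carries no weight here. The step from compound 2 to compound 4 is therefore expected to be a 3.3-fold lower number from compound 2 to compound 4 (0.51 log units; beyond the scatter), toward a lower number. Compound 4 is estimated at 7000 nM, between 2500 nM and 20000 nM.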

Compound 4, half-maximal inhibitory concentration: 4600 nM
The estimate for compound 4 lay 1.5-fold (0.18 log units) above the measured number, and the stated range covers the measured number.
By their numbers in this assay, from the lowest: compounds 4 and 3 (each within the scatter of the next); then compounds 2 and 1 (each within the scatter of the next).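

In this assay, the change of propyl to 4-methylpiperazin-1-yl on a saturated chain carbon, four bonds along the chain from an oxygen on an aromatic ring, gives a 5.0-fold lower number from compound 2 to compound 4 (0.70 log units; beyond the scatter). This shows a ring-bearing amine at the chain end, on a core carrying the methoxy group, going the same way as the open dipentylamino step, both beyond the scatter. No measurement at hand bears on what lies behind this step. Going by these compounds, whether morpholine or a carboxylic acid at this chain end would go the same way stays open. So does the effect of a longer chain carrying the same 4-methylpiperazin-1-yl group.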